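Thiophene-to-pyridine swap on an aminomethyl arm: cytotoxicity outlook

A few compounds are considered here, and "the series" means these few. Any claim that something is new, unique, unknown or untested is made for them only; others in the source may bear on it.

Measured compounds:
- Compound 1, `CCOCCNc1nc(C)c(-c2nc3ccccc3s2)c(N[C@@H]2C[C@H](CO)[C@@H](O)[C@H]2O)n1`, gives 18000 nM in an ADME assay on cells (Homo sapiens) for cytotoxicity, read by polymerase chain reaction, with a stated time of 3 days; on this read-out lower numbers stand for higher toxicity in this test and higher numbers for lower toxicity in this test.
- Compound 2, `Cc1nc(NCc2ccsc2)nc(N[C@@H]2C[C@H](CO)[C@@H](O)[C@H]2O)c1-c1nc2ccccc2s1`, gives 6000 nM in this assay.

Both compounds share a core and differ only on a saturated chain carbon bound to a nitrogen on an aromatic ring. On the two numbers seen so far compound 2 stands lowest, which on this read-out means the higher toxicity of the pair; the step of a 3.0-fold lower number from compound 1 to compound 2 (0.48 log units; beyond the scatter) separates the two and lies beyond the scatter.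

Compound 3, `Cc1nc(NCc2ccncc2)nc(N[C@@H]2C[C@H](CO)[C@@H](O)[C@H]2O)c1-c1nc2ccccc2s1`, has not been measured. Its difference from compound 2 is pyridin-4-yl in place of thiophen-3-yl on a saturated chain carbon bound to a nitrogen on an aromatic ring. For the measured compounds named here, no measured step swaps these two rings, so the one known step, which exchanged a chain for an aromatic ring, is only loosely related and offers no direction for this change. The expectation for compound 3 is therefore a step about the size of the scatter, if any, from compound 2, written as a 1.3-fold higher number from compound 2 to compound 3 (0.12 log units; within the scatter). Compound 3 is thus estimated at 8000 nM, within a range of 3000 nM to 25000 nM.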

Compound 3, half-maximal cytotoxic concentration: 7000 nM
Beside the measured number, compound 3's estimate is 1.1-fold (0.06 log units) above it; low and high end bracket the measured number.
By their numbers in this assay, from the lowest: compounds 2 and 3 (each within the scatter of the next); then compound 1.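

In this assay, putting pyridin-4-yl in place of thiophen-3-yl on a saturated chain carbon bound to a nitrogen on an aromatic ring gives a 1.2-fold higher number from compound 2 to compound 3 (0.07 log units; within the scatter), so the two rings cannot be told apart on this read-out, even though one is five-membered with sulfur and the other six-membered with nitrogen. The gap to the ethoxymethyl compound also holds for the second ring, with a 2.6-fold lower number from compound 1 to compound 3 (0.41 log units; beyond the scatter), so among these three compounds both aromatic rings give a lower number, meaning higher toxicity in this test, than the ethoxymethyl chain does. Nothing available explains why the two rings read alike or why the ethoxymethyl compound stands apart from them.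

With only two aromatic rings and one chain at this place, the compounds shown cannot say whether any aromatic ring would give the same result, such as a plain phenyl ring or a pyridine ring carrying a carboxylic acid. They also leave open how an amine at the end of a longer chain would read at this position, and so whether the chain or the ring is what sets these numbers apart.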